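The compounds below may be only part of what the source reports. "The series", "measured", "known", "first", "only" and "open" are said of these compounds alone.

Measured so far:
- compound 1, `COc1ccc(-c2cc(-c3ccc(S(=O)(=O)N(C)C)cc3)cnc2N)cn1` — > 100 ug/mL in a physicochemical assay for solubility, read by nephelometry, measured as kinetic solubility, at pH 2; on this read-out higher numbers stand for higher solubility and lower numbers for lower solubility
- compound 2, `COc1ccc(-c2cc(-c3ccc(-n4cncn4)cc3)cnc2N)cn1` — > 100 ug/mL in this assay

In this assay compound 1 gives > 100 ug/mL, which is a limit of the assay and not a number. In this assay compound 2 likewise gives > 100 ug/mL, again a limit. Among the measured compounds shown here, both values sit at the limit of > 100 ug/mL in this assay, at which 2 of the 2 values shown sit, so the only measured step, a step that the two limits leave unreadable from compound 1 to compound 2, cannot be read in size or direction.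

Compound 3, `COc1ccc(-c2cc(-c3ccc(-n4cccn4)cc3)cnc2N)cn1`, differs from compound 2 by 1H-pyrazol-1-yl in place of 1H-1,2,4-triazol-1-yl on an aromatic carbon. For the measured compounds named here, no measured step bears on this exchange, and compound 2 itself stands at the limit of this assay, so no direction can be taken from the data. Compound 3 is therefore expected to stay at or near the same limit, with the step of a number no higher from compound 2 to compound 3 (the limit leaves the size open) estimated as nothing beyond the scatter. The estimate for compound 3 in this assay is 100 ug/mL, within 40 ug/mL to 150 ug/mL.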

Compound 3, solubility: > 100 ug/mL
Compound 3: only a limit was reported; the forecaster's own chance of this, stated with the estimate: 65%; the middle value lies on the limit itself.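

In this assay compound 3 gives > 100 ug/mL, a limit and not a number. No step among compound 1, compound 2 and compound 3 can be read in size or direction: the limit of > 100 ug/mL in this assay, at which 3 of the 3 values shown sit.

The compounds shown leave open whether dimethylsulfamoyl, 1H-1,2,4-triazol-1-yl and 1H-pyrazol-1-yl differ at all in this assay.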